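Replacing the Side Chain of Compound 3

The source may hold more compounds than are shown below. What is called first, only, known or untested is meant among the compounds shown, and "the series" means these compounds.

Of the compounds shown here, three sharing one core have been measured in a functional assay with Oryctolagus cuniculus as the target; a lower number here means a stronger inhibitor, a higher number a weaker inhibitor. Compound 1 (`COc1ccc(-c2nc(N=C(N)N)sc2-c2ccc(OC)cc2)cc1`) gives 31000 nM, compound 2 (`COc1ccc(-c2nc(CNC(=O)c3cccnc3)sc2-c2ccc(OC)cc2)cc1`) gives 25 nM, and compound 3 (`COc1ccc(-c2nc(CNC(=O)NC(C)C)sc2-c2ccc(OC)cc2)cc1`) gives 42 nM. Compound 3 therefore stands close to one neighbour and far from the other. The close pair shows a 1.7-fold higher number from compound 2 to compound 3 (0.23 log units; within the scatter), while the distant pair shows a 740-fold lower number from compound 1 to compound 3 (2.87 log units; beyond the scatter).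

Compound 4 (`CCOC(=O)/C(C#N)=C/c1nc(-c2ccc(OC)cc2)c(-c2ccc(OC)cc2)s1`) has not yet been measured. The change is 2-cyano-2-(ethoxycarbonyl)ethenyl in place of ((isopropylcarbamoyl)amino)methyl on an aromatic carbon. Compounds 2 and 3 carry related chains that compound 4 gives up, so their small step offers only weak guidance. Within the data shown here, the closest precedent for a change of chain type is a 1200-fold lower number from compound 1 to compound 2 (3.09 log units; beyond the scatter), which shows how far a swap at this aromatic carbon can move the number. A moderate rise in this assay is expected, with wide uncertainty in either direction. The expected step is a 3.6-fold higher number from compound 3 to compound 4 (0.55 log units; beyond the scatter). For compound 4 the estimated value is 150 nM, with an expected range from 15 nM to 2000 nM.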

Compound 4, half-maximal inhibitory concentration: < 10 nM
Compound 4: no number, only a limit; the forecaster's own chance of this, stated with the estimate: 3%; middle value at least 15-fold (1.17 log units) away from the limit.
By their numbers in this assay, from the lowest: compounds 2 and 3 (each within the scatter of the next); then compound 1. At a limit, below all of these: compound 4.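

In this assay, compound 4 is reported only as a limit: the limit of < 10 nM in this assay, at which 1 of the 4 values shown sits. The 2-cyano-2-(ethoxycarbonyl)ethenyl chain gives an at least 4.2-fold lower number from compound 3 to compound 4 (0.62 log units; beyond the scatter), and against the pyridine-bearing amide chain it gives an at least 2.5-fold lower number from compound 2 to compound 4 (0.39 log units; beyond the scatter), so this aromatic carbon, which lies next to the ring nitrogen and the ring sulfur, can hold a chain with 0 hydrogen-bond donors and still give a lower number than either earlier chain. The gap to the weakest compound also widens, with an at least 3100-fold lower number from compound 1 to compound 4 (3.49 log units; beyond the scatter), showing that swaps at this one carbon span more of the range than compounds 1, 2 and 3 revealed.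

The limit leaves the true size of all three steps open. The compounds shown also do not separate the nitrile, the ethyl ester and the double bond, so a carboxylic acid in place of the ester, or a saturated chain, would be the next informative comparison.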